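Swapping the Five-Membered Ring and the Expected Solubility

The compounds below may be only part of what the source reports. "The series", "measured", "known", "first", "only" and "open" are said of these compounds alone.

Compound 1 `CC(C)CN1C(=O)c2ccccc2[C@H](C(=O)Nc2ccc(F)c(C#N)c2)[C@H]1c1ccsc1`: < 1000 nM in a physicochemical assay for solubility, in phosphate buffer, with a stated time of 18 h, at pH 7; on this read-out lower numbers stand for lower solubility and higher numbers for higher solubility.
Compound 2 `CC(C)CN1C(=O)c2ccccc2[C@H](C(=O)Nc2ccc(F)c(C#N)c2)[C@H]1c1ccoc1`: 15000 nM in this assay.

For compound 1 the reading is a limit of this assay and not a number (the limit of < 1000 nM in this assay, at which 1 of the 2 values shown sits). Compound 2 therefore holds the only number shown. Compound 3 `CC(C)CN1C(=O)c2ccccc2[C@H](C(=O)Nc2ccc(F)c(C#N)c2)[C@H]1c1ccc(C#N)s1` differs from compound 2 by 5-cyanothiophen-2-yl in place of furan-3-yl on a saturated ring carbon. Among the compounds with values here, the one measured step bearing on this change is an at least 15-fold higher number from compound 1 to compound 2 (1.17 log units; beyond the scatter), where exchanging thiophene for furan went with a large rise. Returning to a thiophene ring, now carrying a nitrile, is expected to move the reading back down; for compound 3 the expected step is a 7.5-fold lower number from compound 2 to compound 3 (0.88 log units; beyond the scatter). Compound 3 is estimated at 2000 nM, within 500 nM to 8000 nM.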

Compound 3, solubility: 4900 nM
The estimate for compound 3 lay 2.5-fold (0.39 log units) below the measured number; low and high end bracket the measured number.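

In this assay, 5-cyanothiophen-2-yl in place of furan-3-yl went with a 3.1-fold lower number from compound 2 to compound 3 (0.49 log units; beyond the scatter), while the same group in place of thiophen-3-yl went with an at least 4.9-fold higher number from compound 1 to compound 3 (0.69 log units; beyond the scatter). A thiophene on this saturated ring carbon is thus not tied to the low reading, so sulfur in the ring does not by itself set the outcome. The comparison has one bound only, since compound 1 stands at a limit and not a number: the limit of < 1000 nM in this assay, at which 1 of the 3 values shown sits.

Going by these compounds, whether the nitrile or the change from thiophen-3-yl to a thiophen-2-yl attachment carries the difference stays open. Also open, on these data alone, is how a thiophene bearing an amine or a carboxylic acid would read in this assay.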